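Triazole for Pyrazole on the Benzylic Aryl Ring

This account rests on a few compounds, and the source may have more. Where it says the series, first, only, none or still open, it means among the compounds named here.

Measured so far:
compound 1 `Cc1cc(C)c(NC(=O)N(Cc2ccc(-c3nnc(C)o3)cc2)C2CCCCCC2)c(C)c1` — 27 nM
compound 2 `Cc1cc(C)c(NC(=O)N(Cc2ccc(-c3cccnc3)cc2)C2CCCCCC2)c(C)c1` — 130 nM
compound 3 `Cc1cc(C)c(NC(=O)N(Cc2ccc(-c3cnn(C)c3)cc2)C2CCCCCC2)c(C)c1` — 47 nM

Three ureas built on one shared core differ only in the aromatic group carried on the benzyl ring, and all three have been tested in an assay on microsomes from intestine for inhibition of acyl-CoA:cholesterol acyltransferase (Oryctolagus cuniculus); a higher number here means a weaker inhibitor, a lower number a stronger inhibitor. Compound 3 gives 47 nM, the second highest of the three numbers. The step of a 1.7-fold higher number from compound 1 to compound 3 (0.24 log units; within the scatter) lies within the scatter, whereas a 2.8-fold lower number from compound 2 to compound 3 (0.44 log units; beyond the scatter) lies beyond it, and a 4.8-fold higher number from compound 1 to compound 2 (0.68 log units; beyond the scatter) is the largest gap in the set.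

Compound 4 `Cc1cc(C)c(NC(=O)N(Cc2ccc(-n3cncn3)cc2)C2CCCCCC2)c(C)c1` has not yet been measured in this assay. It differs from compound 3 in a single place: 1H-1,2,4-triazol-1-yl in place of 1-methyl-1H-pyrazol-4-yl on an aromatic carbon. For the measured compounds named here, the nearest precedent is the step of a 1.7-fold higher number from compound 1 to compound 3 (0.24 log units; within the scatter), which also exchanges one five-membered aromatic ring for another and moved the number only a little. The larger step of a 4.8-fold higher number from compound 1 to compound 2 (0.68 log units; beyond the scatter) brought in a six-membered ring, and the group entering compound 4 is five-membered, so that step bears less directly. Compound 4 is therefore expected to land close to compound 3. The expected step is a 1.2-fold higher number from compound 3 to compound 4 (0.07 log units; within the scatter). Compound 4 is estimated at 55 nM, with a range from 20 nM to 160 nM.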

Compound 4, half-maximal inhibitory concentration: 26 nM
The estimate for compound 4 lay 2.1-fold (0.33 log units) above the measured number; the range from low to high includes it.
By their numbers in this assay, from the lowest: compounds 4, 1 and 3 (each within the scatter of the next); then compound 2.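

With 1H-1,2,4-triazol-1-yl on the aromatic carbon para to a large group, a third five-membered aromatic ring has been read in this assay, and neither comparison with the other two separates it: a 1.8-fold lower number from compound 3 to compound 4 (0.26 log units; within the scatter) stays within the scatter against 1-methyl-1H-pyrazol-4-yl, as does a 1.0-fold lower number from compound 1 to compound 4 (0.02 log units; within the scatter) against 5-methyl-1,3,4-oxadiazol-2-yl. Pyridin-3-yl alone stands apart, with a 5.0-fold lower number from compound 2 to compound 4 (0.70 log units; beyond the scatter) beyond the scatter, so all three five-membered rings now sit clear of the one six-membered ring in this set, and compound 2 is the weakest inhibitor of the four. Nothing in the data given explains this split or the tolerance among the five-membered rings.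

With a single six-membered ring in the set, the compounds shown leave open whether the gap belongs to six-membered rings in general or to pyridin-3-yl alone, which a plain phenyl or a pyridin-4-yl group at this position would help to settle. They also leave open whether an aromatic ring is needed here at all, since no open-chain group, such as a carboxylic acid or an amine on a short chain, appears among them.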